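Sulfur to selenium on the shared core: cytotoxicity outlook

This account rests on a few compounds, and the source may have more. Where it says the series, first, only, none or still open, it means among the compounds named here.

Measured compounds:
compound 1, `C[Se]c1nc(NCc2ccccc2)c2ccccc2n1`: > 100000 nM
compound 2, `CSc1ccc(CNc2nc(SC)nc3ccccc23)cc1`: > 100000 nM

Both numbers come from a functional assay on MCF7 cells (Homo sapiens) for cytotoxicity, read by MTT assay, with a stated time of 72 h; on this read-out lower numbers stand for higher toxicity in this test and higher numbers for lower toxicity in this test. For compound 1 the value > 100000 nM is a limit of the assay and not a number. For compound 2 the value > 100000 nM is likewise a limit. Compound 2 therefore stands at the limit of > 100000 nM in this assay, at which 2 of the 2 values shown sit. Within the data shown here, no step between two measured compounds can be drawn here; the two values show only that neither compound reached the measurable range.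

Compound 3, `CSc1ccc(CNc2nc([Se]C)nc3ccccc23)cc1`, differs from compound 2 in one place: a group of 2 heavy atoms (1 carbon, 1 selenium; no ring) in place of a group of 2 heavy atoms (1 carbon, 1 sulfur; no ring), on an aromatic carbon. Among the measured compounds shown here, the group that enters is the one compound 1 already carries at the same position of the shared core, while the rest of compound 3 matches compound 2.

Because compound 1 already sits at its limit > 100000 nM with this group in place, compound 3 is expected to give 100000 nM, within 20000 nM to 500000 nM. The expected step is a number no higher from compound 2 to compound 3 (the limit leaves the size open), that is, nothing beyond the scatter, and most likely another limit rather than a number.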

Compound 3, concentration lethal to 50% of the cells: > 100000 nM
Compound 3 gave a limit, no number (the forecaster's own chance of this, stated with the estimate: 75%); the middle value sits exactly at the limit.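

In this assay compound 3 gives > 100000 nM, which is a limit and not a number. The steps to compound 3 from compound 1 and from compound 2 therefore cannot be read: the limit of > 100000 nM in this assay, at which 3 of the 3 values shown sit. The compounds shown leave open whether putting the selenium group in place of methylsulfanyl changes cytotoxicity at all.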